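The compounds below may be only part of what the source reports. "The series", "measured", "known", "first", "only" and "open" are said of these compounds alone.

Measured compounds in an ADME assay on MCF7 cells (Homo sapiens) for cytotoxicity, read by CellTiter-Glo, with a stated time of 24 h; a lower number here means a stronger inhibitor of growth, a higher number a weaker inhibitor of growth:
Compound 1 `CC1=C(C(=O)OCc2ccccc2)C(c2ccc(Cl)cc2Cl)NC(=O)N1CCCC(=O)OCc1ccccc1` gives > 100000 nM, a limit of the assay.
Compound 2 `CC1=C(C(=O)OCc2ccccc2)C(c2ccc(Cl)cc2Cl)NC(=O)N1CCCC(=O)OCC#N` gives > 100000 nM, a limit of the assay.
Compound 3 `CC1=C(C(=O)OCc2ccccc2)C(c2ccc(Cl)cc2Cl)NC(=O)N1CCCC(=O)OCc1ccc2ccccc2n1` gives > 100000 nM, a limit of the assay.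

Compound 3 stands at the limit of > 100000 nM in this assay, at which 3 of the 3 values shown sit; its value is a limit, not a number. The three measured steps all vary the group on the saturated chain carbon bound to an oxygen next to a carbonyl group: a step that the two limits leave unreadable from compound 1 to compound 2, a step that the two limits leave unreadable from compound 1 to compound 3 and a step that the two limits leave unreadable from compound 2 to compound 3. None of them has a readable size, so neither a direction nor a magnitude can be drawn from them.

Compound 4 `CC1=C(C(=O)OCc2ccccc2)C(c2ccc(Cl)cc2Cl)NC(=O)N1CCCC(=O)OCc1ccccn1` differs from compound 3 in one place: pyridin-2-yl in place of quinolin-2-yl on a saturated chain carbon bound to an oxygen next to a carbonyl group. The measured steps bear on the same position, but each is unreadable, so they supply no measured size for a change of this kind. With every measured value sitting at the limit, the expectation is that compound 4 likewise gives no number in this assay. The step expected is a step that the limit leaves unreadable from compound 3 to compound 4, that is, essentially none. The estimate for compound 4 is 150000 nM, between 50000 nM and 1000000 nM, most likely reported again only as a limit.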

Compound 4, concentration for 50% growth inhibition: > 100000 nM
Compound 4 ended at the assay's limit (the forecaster's own chance of this, stated with the estimate: 85%); the middle value lies beyond the limit too.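

In this assay compound 4 gives > 100000 nM, a limit and not a number. Its steps from compound 1, compound 2 and compound 3 therefore cannot be read, and none has a size: the limit of > 100000 nM in this assay, at which 4 of the 4 values shown sit.

The compounds shown leave open whether any group on the saturated chain carbon bound to an oxygen next to a carbonyl group gives a measurable value.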